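A few compounds are considered here, and "the series" means these few. Any claim that something is new, unique, unknown or untested is made for them only; others in the source may bear on it.

Measured so far:
compound 1 `CCNC(=O)[C@@H]1CO[C@@H](n2cnc3c(N)ncnc32)[C@@H]1O` with 10%
compound 2 `Nc1ncnc2c1ncn2[C@@H]1OC[C@H](CO)[C@H]1O` with 32%

Two compounds carry a reading in an assay on CHO cells for displacement of a labelled ligand from adenosine receptor A3 (Homo sapiens), tested at 10 uM; a lower number here means less inhibition, a higher number more inhibition at the concentration tested (going by the name of the read-out). Compound 1, `CCNC(=O)[C@@H]1CO[C@@H](n2cnc3c(N)ncnc32)[C@@H]1O`, gives 10% in this assay. Compound 2, `Nc1ncnc2c1ncn2[C@@H]1OC[C@H](CO)[C@H]1O`, gives 32% in this assay, which is the higher of the two numbers; the gap to compound 1 is beyond the usual scatter of repeated measurements.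

The next compound, compound 3, `Nc1ncnc2c1ncn2[C@@H]1OC[C@@H](CO)[C@H]1O`, is not yet measured. It differs from compound 2 as follows: the two compounds have the same atoms and bonds and differ only in configuration as drawn: 1 of 3 stereo elements differ; a stereocentre at a saturated ring carbon is drawn S in compound 2 and R in compound 3. Within the data shown here, no step between two measured compounds of this kind is available, so there is no direct precedent for a change of configuration alone. For compound 3 a modest decrease from compound 2 is expected, a number 12 percentage points lower from compound 2 to compound 3 (beyond the scatter), at the edge of the scatter rather than clearly beyond it. Compound 3 is therefore estimated to give 20% in this assay, within a range of 4% to 44%.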

Compound 3, a percentage reported as inhibition, at one concentration (the size of the read-out at that concentration, not a potency): 7%
The estimate for compound 3 lay 13 percentage points above the measured number, within the range that was stated.
By their numbers in this assay, from the lowest: compounds 3 and 1 (each within the scatter of the next); then compound 2.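

In this assay, among these compounds, the step of a number 25 percentage points lower from compound 2 to compound 3 (beyond the scatter) gives the first reading of a change of configuration alone, and it shows that how this one saturated ring carbon is drawn matters for the reading even with the hydroxymethyl group kept in place. With the configuration of compound 3, hydroxymethyl in place of ethylcarbamoyl on a saturated ring carbon gives a number 3 percentage points lower from compound 1 to compound 3 (within the scatter) and so does not separate the two groups in this assay. The first step can be laid to that single stereocentre, because nothing else separates the pair: the fact that compounds 2 and 3 differ only in the configuration as drawn

As far as these compounds go, whether inverting this centre would shift the reading in the same way with ethylcarbamoyl on the ring carbon stays open, as does how a carboxylic acid or an amine there would read. These readings come from a single concentration, so they leave the potency of all three compounds open.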